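From methylamino to dimethylamino: notes on compound 4

The compounds below may be only part of what the source reports. "The series", "measured", "known", "first", "only" and "open" are said of these compounds alone.

Measured so far in a functional assay on A549 cells (Homo sapiens) for antiproliferative activity, read by MTT assay, with a stated time of 48 h; on this read-out higher numbers stand for weaker inhibition and lower numbers for stronger inhibition:
- compound 1 `COc1ccc(C(=O)c2cc(OC)c(OC)c(OC)c2)c(NC(=O)CN(C)C)c1` gives 590 nM
- compound 2 `C=C(c1ccc(OC)cc1NC(=O)CNC)c1ccc(OC)c2c1OC(C)(C)C=C2` gives 150 nM
- compound 3 `C=C(c1ccc(OC)cc1NC(=O)CNC)c1ccc(OC)c2c1C=CC(C)(C)O2` gives 320 nM

Compound 2 (150 nM) has the lowest number of the three. Compound 3 (320 nM) and compound 1 (590 nM) both read higher, each beyond the usual scatter, which makes compound 2 the strongest inhibitor measured in this small set.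

The next compound, compound 4 `C=C(c1ccc(OC)cc1NC(=O)CN(C)C)c1ccc(OC)c2c1OC(C)(C)C=C2`, differs from compound 2 at a single place: methyl in place of hydrogen on an amine nitrogen. This is methyl in place of hydrogen on an amine nitrogen, turning methylamino into dimethylamino. Among the compounds with values here, no measured pair isolates this change, so there is no direct precedent for its size. Only compound 1 (590 nM) already carries dimethylamino, but its core differs from that of compound 2, so its number cannot be credited to the amine alone.

A small step is expected in this assay, leaning towards a higher number and probably staying within the scatter. The expected change is a 1.5-fold higher number from compound 2 to compound 4 (0.17 log units; within the scatter) (an estimate only). The estimated value for compound 4 is 220 nM (expected range 90 nM to 550 nM).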

Compound 4, half-maximal inhibitory concentration: 270 nM
Beside the measured number, compound 4's estimate is 1.2-fold (0.09 log units) below it, and the stated range covers the measured number.
By their numbers in this assay, from the lowest: compounds 2, 4, 3 and 1 (each within the scatter of the next, the first and the last beyond it).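

In this assay, the change from methylamino to dimethylamino on the amine nitrogen now has its first matched pair, which reads a 1.8-fold higher number from compound 2 to compound 4 (0.26 log units; within the scatter). On the shared core the amine nitrogen therefore carries a second methyl with no difference that can be told apart from repeat scatter, and compound 4 reads 270 nM. The hydrogen on this nitrogen is thus not required for activity at the resolution of this read-out, although a single pair gives a single reading, and nothing on hand bears on the reason for the two numbers.

The compounds shown leave open how far this position can be taken beyond methyl: an ethyl group on the same nitrogen, a longer chain there, or the unsubstituted primary amine would each test it further. Within the data shown here, it is also open whether the same step holds on the core of compound 3 or of compound 1, as the pair of compound 2 and compound 4 is the only one that carries this change.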